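The source may hold more compounds than are shown below. What is called first, only, known or untested is meant among the compounds shown, and "the series" means these compounds.

Compound 3 `Nc1nc(N2CCN(C(=O)COc3ccc(Cl)cc3)CC2)c2ccsc2n1` gives 330 nM in a functional assay on cells (Lymphocyte) (on this read-out lower numbers stand for stronger inhibition and higher numbers for weaker inhibition), the lowest of the two numbers reported. Compound 1 `Nc1nc(N2CCN(C(=O)COc3ccc(Cl)cc3)CC2)c2cc(F)sc2n1` gives 700 nM in this assay, and the step of a 2.1-fold lower number from compound 1 to compound 3 (0.33 log units; beyond the scatter) is a modest one. Compound 2 `Nc1nc(N2CCN(C(=O)c3cccnc3)CC2)c2cc(F)sc2n1` gives only a limit of the assay, > 10000 nM. Compound 2 sits at the limit of > 10000 nM in this assay, at which 1 of the 3 values shown sits. The step of an at least 14-fold higher number from compound 1 to compound 2 (1.15 log units; beyond the scatter) is large. Compound 4 `Nc1nc(N2CCN(C(=O)COc3ccc(Br)cc3)CC2)c2ccsc2n1` differs from compound 3 by bromo in place of chloro on an aromatic carbon. Neither measured step touches this change: one replaces the whole (4-chlorophenoxy)methyl group, the other exchanges fluoro for hydrogen on the shared core. For the measured compounds named here, with no measured step bearing on it, compound 4 is expected to differ from compound 3 by no step beyond the scatter, a 1.1-fold lower number from compound 3 to compound 4 (0.04 log units; within the scatter). Compound 4 is estimated at 300 nM in this assay, with a range from 120 nM to 800 nM.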

Compound 4, half-maximal inhibitory concentration: 320 nM
Compound 4: the middle estimate sits 1.1-fold (0.03 log units) below what was measured, and the stated range covers the measured number.
By their numbers in this assay, from the lowest: compounds 4 and 3 (each within the scatter of the next); then compound 1. At a limit, above all of these: compound 2.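

For the compounds shown here, exchanging chloro for bromo on the phenoxy ring gives a 1.0-fold lower number from compound 3 to compound 4 (0.01 log units; within the scatter) in this assay, and this is the first measured change at this position. The position para to a large group therefore takes either halogen, with no difference that can be told from the scatter. Nothing measured here offers a reason for this.

As far as these compounds go, whether a methoxy group, a nitrile or an amine at this position would give a similar number remains open. So does whether bromo behaves the same way on the fluoro-bearing core of compound 1.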